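A few compounds are considered here, and "the series" means these few. Any claim that something is new, unique, unknown or untested is made for them only; others in the source may bear on it.

Measured compounds:
Compound 1 `Cc1cc(C)c(Oc2cc(Nc3ccc(C#N)cc3)ncc2C(=O)NCc2cn(Cc3ccccc3[N+](=O)[O-])nn2)c(C)c1` gives > 212000 nM in an ADME assay on MT4 cells (Homo sapiens) for cytotoxicity, read by MTT assay, with a stated time of 5 days; a higher number here means that more compound is tolerated, a lower number that less compound is tolerated.
Compound 2 `Cc1cc(C)c(Oc2cc(Nc3ccc(C#N)cc3)ncc2C(=O)NCc2cn(CC(N)=O)nn2)c(C)c1` gives 24000 nM.
Compound 3 `Cc1cc(C)c(Oc2cc(Nc3ccc(C#N)cc3)ncc2C(=O)NCc2cn(Cc3cccc(Cl)c3)nn2)c(C)c1` gives 187000 nM.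

Compound 1 is reported at a limit of this assay and not a number (the limit of > 212000 nM in this assay, at which 1 of the 3 values shown sits). Among the two numbers proper, compound 3 gives the highest; compound 2 lies a clear step below it, as the step of a 7.8-fold higher number from compound 2 to compound 3 (0.89 log units; beyond the scatter) shows, and in the other direction the step of an at least 8.8-fold lower number from compound 1 to compound 2 (0.94 log units; beyond the scatter) is at least as large.

Compound 4 `Cc1cc(C)c(Oc2cc(Nc3ccc(C#N)cc3)ncc2C(=O)NCc2cn(Cc3ccc([N+](=O)[O-])cc3)nn2)c(C)c1` differs from compound 3 in one place: 4-nitrophenyl in place of 3-chlorophenyl on a saturated chain carbon bound to an aromatic nitrogen. The step that bears most directly on it is an at least 1.1-fold lower number from compound 1 to compound 3 (0.05 log units; that floor lies within the scatter), which exchanged one nitrophenyl for the same chlorophenyl and stayed within the scatter, though it begins at a limit. The steps involving the carbamoyl group do not touch a nitrophenyl and so offer little guidance here.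

From this, compound 4 is expected to show a step of about a 1.0-fold higher number from compound 3 to compound 4 (0.01 log units; within the scatter), no larger than the scatter. The estimate for compound 4 is 190000 nM, between 80000 nM and 212000 nM, with a fair chance that only a limit is reported.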

Compound 4, half-maximal cytotoxic concentration: >= 139000 nM
Compound 4 gave a limit, no number (the forecaster's own chance of this, stated with the estimate: 40%); the middle value does not contradict the limit.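

The 4-nitrobenzyl group gives a third aryl-bearing compound, after compound 1 and compound 3, that stands apart from the carbamoyl group on a saturated chain carbon bound to an aromatic nitrogen, with an at least 5.7-fold higher number from compound 2 to compound 4 (0.76 log units; beyond the scatter). In this assay compound 4 is reported as a limit and not a number: the limit of >= 139000 nM in this assay, at which 1 of the 4 values shown sits. The steps from compound 3 and from compound 1 to compound 4 cannot be read, and 4-nitrophenyl therefore cannot be placed in order against 3-chlorophenyl or 2-nitrophenyl.

On these data alone, compound 1 and compound 4 are both limits, and whether 2-nitrophenyl and 4-nitrophenyl differ at all stays open. What an amine, a carboxylic acid or a longer chain at this place would give also stays open, since the compounds shown carry only substituted phenyl groups and a carbamoyl group here.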